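This account rests on a few compounds, and the source may have more. Where it says the series, first, only, none or still open, it means among the compounds named here.

Compound 3 `CCn1cc(-c2nc3ccc(N)cc3[nH]2)c(=O)c2cc(F)c(N3CCNCC3)cc21` sits at the ceiling of a functional assay on K562 cells (Homo sapiens) for cytotoxicity, read by sulforhodamine B assay, with a stated time of 48 h; on this read-out higher numbers stand for weaker inhibition and lower numbers for stronger inhibition: it gives only a limit, > 10000 nM, so its true position is not read. Compound 1 `CCn1cc(-c2nc3ccccc3[nH]2)c(=O)c2cc(F)c(N3CCNCC3)cc21` also returns only a limit, > 10000 nM. Compound 2 `CCn1cc(-c2nc3ccc(Cl)cc3[nH]2)c(=O)c2cc(F)c(N3CCNCC3)cc21` gives a number, 2700 nM, and the step of an at least 3.7-fold higher number from compound 2 to compound 3 (0.56 log units; beyond the scatter) is read only against the limit (the limit of > 10000 nM in this assay, at which 2 of the 3 values shown sit). Compound 4 `CCn1cc(-c2nc3ccc(N)cc3[nH]2)c(=O)c2cc(F)c(N3CCN(C)CC3)cc21` differs from compound 3 by methyl in place of hydrogen on an amine nitrogen in a ring. Among the compounds with values here, none of the measured steps touches the amine nitrogen in the ring; all concern the aromatic carbon, so no measured step bears on this change. Compound 4 is therefore expected to stay close to compound 3, with the step that the limit leaves unreadable from compound 3 to compound 4 expected to lie within the scatter. The estimate for compound 4 in this assay is 15000 nM, in the range 5000 nM to 50000 nM, most likely again reported only as a limit.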

Compound 4, half-maximal inhibitory concentration: > 10000 nM
Compound 4: only a limit was reported (the forecaster's own chance of this, stated with the estimate: 70%); the middle value lies beyond the limit too.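

Compound 3 and compound 4 both stop at a limit in this assay, so the step between them cannot be read: the limit of > 10000 nM in this assay, at which 3 of the 4 values shown sit.

As far as these compounds go, whether piperazin-1-yl to 4-methylpiperazin-1-yl changes cytotoxicity at all stays open, as do the true positions of compound 3 and compound 4.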